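The source may hold more compounds than are shown below. What is called first, only, known or untested is meant among the compounds shown, and "the series" means these compounds.

Of the compounds shown here, three built on one shared core have been measured in an assay for inhibition of 6-phosphofructo-2-kinase/fructose-2,6-bisphosphatase 3 (Homo sapiens), read by ADP-Glo, with a stated time of 2 h; a lower number here means a stronger inhibitor, a higher number a weaker inhibitor. Compound 1 `Cn1ccc2ccc(-c3cc(Nc4ccccc4S(=O)(=O)Nc4cncnc4)cc4nccnc34)cc21` gives 1690 nM. Compound 2 `CN1CCC(NS(=O)(=O)c2ccccc2Nc2cc(-c3ccc4ccn(C)c4c3)c3nccnc3c2)C1` gives 33 nM, and compound 3 `CN(Cc1cncnc1)S(=O)(=O)c1ccccc1Nc1cc(-c2ccc3ccn(C)c3c2)c2nccnc2c1` gives 62 nM. Compound 3 therefore stands second highest of the three numbers: compound 2 lies within the scatter of it, while the gap to compound 1 is large, as a 27-fold lower number from compound 1 to compound 3 (1.44 log units; beyond the scatter) shows.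

Compound 4 `Cn1ccc2ccc(-c3cc(Nc4ccccc4S(=O)(=O)NCC4CCOCC4)cc4nccnc34)cc21` has not yet been measured. It differs from compound 3 in one place: ((oxan-4-yl)methyl)amino in place of methyl((pyrimidin-5-yl)methyl)amino on a sulfonyl sulfur. Within the data shown here, two measured steps bear on such a change. Replacing the (pyrimidin-5-yl)amino group gave large improvements both times: a 51-fold lower number from compound 1 to compound 2 (1.71 log units; beyond the scatter) and a 27-fold lower number from compound 1 to compound 3 (1.44 log units; beyond the scatter). Between those two replacements the difference was small: a 1.9-fold higher number from compound 2 to compound 3 (0.27 log units; within the scatter). Compound 4, like compound 2 with its 33 nM, carries a saturated ring on the sulfonamide nitrogen, so no step beyond the scatter is expected in this assay; the expected step is a 1.2-fold lower number from compound 3 to compound 4 (0.09 log units; within the scatter). Compound 4 is estimated at 50 nM, with a range from 15 nM to 200 nM.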

Compound 4, half-maximal inhibitory concentration: 26 nM
Compound 4: middle estimate off by 1.9-fold (0.28 log units), on the high side; the measured number falls inside the stated range.
By their numbers in this assay, from the lowest: compounds 4, 2 and 3 (each within the scatter of the next, the first and the last beyond it); then compound 1.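

Within this assay, the change on the sulfonyl sulfur gives a 2.4-fold lower number from compound 3 to compound 4 (0.38 log units; beyond the scatter), a modest step beyond the scatter, so a six-membered non-aromatic ring with one oxygen serves at least as well here as the pyrimidine-bearing group. Against the 1-methylpyrrolidin-3-yl group, the step is a 1.3-fold lower number from compound 2 to compound 4 (0.10 log units; within the scatter), which lies within the scatter, while a 65-fold lower number from compound 1 to compound 4 (1.81 log units; beyond the scatter) makes (oxan-4-yl)methyl the third group on the sulfonamide nitrogen to give a large step away from pyrimidin-5-yl. No measurement here explains why these groups differ from one another.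

From the compounds shown here alone, the step from compound 3 to compound 4 removes the nitrogen methyl and swaps the ring together, so the share of each remains unknown. Going by these compounds, whether an open chain such as n-butyl, or a carboxylic acid, would fit this position also remains open.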